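This account rests on a few compounds, and the source may have more. Where it says the series, first, only, none or still open, it means among the compounds named here.

Measured so far in a functional assay on L02 cells (Homo sapiens) for inhibition, read by Griess assay, with stated times of 1 h and 24 h; a lower number here means a stronger inhibitor, a higher number a weaker inhibitor:
compound 1 `CCCc1nn(C)c2c(NCc3ccc(F)cc3)nc(/C=C/c3nc(C)c(C)nc3C)nc12` — > 1000000 nM, a limit of the assay rather than a number.
compound 2 `Clc1ccc(CNc2nc(/C=C/c3ccco3)nc3ccsc23)cc1` — > 1000000 nM, likewise a limit.
compound 3 `COc1cc(/C=C/c2nc(Nc3ccc(C(F)(F)F)cc3)c3sccc3n2)cc(OC)c1OC` — 436000 nM.

For the measured compounds named here, compound 3 is the only compound of the three with a measured number in this assay, and that number is weak; the other two sit at the limit. Going by the values given here, no pair among the three differs in a single place, so no step can be read between measured compounds; all the two limits show is that compounds 1 and 2 gave no measurable half-maximal inhibitory concentration.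

Compound 4 `COc1cc(/C=C/c2nc(NCc3ccncc3)c3sccc3n2)cc(OC)c1OC` is not yet measured. It differs from compound 3 in one place: (pyridin-4-yl)methyl in place of 4-(trifluoromethyl)phenyl on a nitrogen on an aromatic ring. The rest of the structure is shared with compound 3.

Among the compounds with values here, with only one number available and the others at the limit, the expectation for this step leans on the limit of > 1000000 nM in this assay, at which 2 of the 3 values shown sit: the series as measured is weak throughout. The step is expected to weaken rather than strengthen, a 2.1-fold higher number from compound 3 to compound 4 (0.31 log units; beyond the scatter), with a real chance that compound 4 is reported only as a limit. Compound 4 is therefore estimated at 900000 nM, in the range 300000 nM to 3000000 nM.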

Compound 4, half-maximal inhibitory concentration: 374000 nM
For compound 4 the middle estimate is 2.4-fold (0.38 log units) above the measured one, within the range that was stated.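

In this assay, (pyridin-4-yl)methyl in place of 4-(trifluoromethyl)phenyl on a nitrogen on an aromatic ring gives a 1.2-fold lower number from compound 3 to compound 4 (0.07 log units; within the scatter), so this change leaves the two compounds indistinguishable. At this position, a group with a six-membered aromatic ring of carbon only and a group with a six-membered aromatic ring holding a hetero atom and a hydrogen-bond acceptor therefore read alike, and the shared structure now has two numbers rather than one. Compound 1 and compound 2 remain limits of the assay rather than numbers: the limit of > 1000000 nM in this assay, at which 2 of the 4 values shown sit.

Steps to compound 1 and compound 2 cannot be read, so the compounds shown do not separate the contribution of this nitrogen substituent from that of the rest of each structure. Still open, going by these compounds, is whether any group at this nitrogen moves the number beyond the scatter, for example a morpholine, a carboxylic acid or a longer alkyl chain, since a single step within the scatter does not settle how much this position can change the result in this assay.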